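A few compounds are considered here, and "the series" means these few. Any claim that something is new, unique, unknown or untested is made for them only; others in the source may bear on it.

Compound 1 `CC[C@H](C)[C@H](N)CN(C(=O)[C@@H]1C[C@H]1c1cccc(C#N)c1)c1ccc(-c2ccccc2)cc1` gives 1600 nM in a functional assay for agonist activity at G protein-coupled receptor 88 (Homo sapiens), read by HTRF and cAMP accumulation; a lower number here means that less compound is needed, a higher number that more compound is needed for the effect. Compound 2 `CC[C@H](C)[C@H](N)CN(C(=O)[C@@H]1C[C@H]1c1ncccn1)c1ccc(-c2ccccc2)cc1` gives 130 nM. Compound 3 `CC(C)C[C@H](N)CN(C(=O)[C@@H]1C[C@H]1c1ccccc1)c1ccc(-c2ccsc2)cc1` gives 1200 nM.

Compound 3 stands second highest of these three numbers. Its value and that of compound 1 sit within the scatter of each other, so no order between them is claimed, while compound 2 lies well beyond the scatter with the lowest number shown. Compound 4 `COc1ccccc1-c1ccc(N(C[C@@H](N)CC(C)C)C(=O)[C@@H]2C[C@H]2c2ccccc2)cc1` differs from compound 3 by 2-methoxyphenyl in place of thiophen-3-yl on an aromatic carbon. Among the compounds with values here, the single measured step, a 12-fold lower number from compound 1 to compound 2 (1.09 log units; beyond the scatter), concerns the group on a saturated ring carbon, not the six-membered aromatic ring of carbon only where this change sits, so it does not bear on it. Within the data shown here, with no step to guide it, the expected change is a 1.2-fold lower number from compound 3 to compound 4 (0.08 log units; within the scatter), within the scatter. Compound 4 is therefore estimated at 1000 nM, between 300 nM and 4000 nM.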

Compound 4, half-maximal effective concentration: 3200 nM
The estimate for compound 4 lay 3.2-fold (0.51 log units) below the measured number; the measured number falls inside the stated range.
By their numbers in this assay, from the lowest: compound 2; then compounds 3, 1 and 4 (each within the scatter of the next, the first and the last beyond it).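

Replacing thiophen-3-yl with 2-methoxyphenyl on this aromatic carbon, para to a large group, gives a 2.7-fold higher number from compound 3 to compound 4 (0.43 log units; beyond the scatter) in this assay. Within the data shown here, this is the first step at this position, and it shows that the number responds to the group placed there, which the earlier compounds could not show. Nothing available gives a reason for the shift. The compounds shown leave open whether the step follows the methoxy group or the six-membered ring that carries it, and how an amine or a carboxylic acid on that ring would read.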